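Benzylamino in place of hydroxy on a carbonyl carbon

The source may hold more compounds than are shown below. What is called first, only, known or untested is meant among the compounds shown, and "the series" means these compounds.

In a functional assay (brain) for inhibition, with Rattus norvegicus as the target (a lower number here means a stronger inhibitor, a higher number a weaker inhibitor), compound 2 `COc1cc2c(cc1O)C(=O)CC(C(=O)O)O2` reports only a limit, > 300000 nM, and not a number. Compound 4 `COc1cc2c(cc1O)C(=O)CC(C(=O)NCc1ccccc1)O2` differs from compound 2 as follows: benzylamino in place of hydroxy on a carbonyl carbon. For the measured compounds named here, no measured step matches this change directly. The nearest evidence comes from two amides: compound 1 `COc1cc2c(cc1O)CCC(C(=O)Nc1ccccc1)O2` gives 6900 nM and compound 3 `CCCCNC(=O)C1CCc2cc(O)c(OC)cc2O1` gives 51300 nM. Going by the values given here, the only measured step, a 7.4-fold higher number from compound 1 to compound 3 (0.87 log units; beyond the scatter), is butyl in place of phenyl on an amide-type nitrogen. Given these two values, a clear move to a lower number, meaning a stronger inhibitor, is expected, estimated as an at least 20-fold lower number from compound 2 to compound 4 (1.30 log units; beyond the scatter). For compound 4 the estimate is 15000 nM, with an expected range of 3000 nM to 80000 nM.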

Compound 4, half-maximal inhibitory concentration: > 300000 nM
Compound 4: no number, only a limit; the forecaster's own chance of this, stated with the estimate: 10%; middle value at least 20-fold (1.30 log units) from the limit.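

Compound 2 and compound 4 each give only a limit in this assay, not a number, so no step between them can be read: the limit of > 300000 nM in this assay, at which 2 of the 4 values shown sit.

On these data alone, whether benzylamino in place of hydroxy on a carbonyl carbon changes inhibition at all remains open.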